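The source may report more compounds than this note shows. Statements on the series, on what has been measured and on what is new or still open speak of the compounds shown alone.

Compound 1 `COc1ccc(C2=C(c3ccccc3)C(=O)N3CCCC3C2)cc1`: 390 nM
Compound 2 `COc1ccc(C2=C(c3cccs3)C(=O)N3CCCC3C2)cc1`: 5000 nM
Compound 3 `COc1ccc(C2=C(c3ccoc3)C(=O)N3CCCC3C2)cc1`: 3000 nM

In a functional assay on HCT-116 cells (Homo sapiens) for cytotoxicity (a lower number here means a stronger inhibitor, a higher number a weaker inhibitor), compound 1 stands at the lowest of the three numbers. Its nearest neighbour is reached by the step of a 7.7-fold higher number from compound 1 to compound 3 (0.89 log units; beyond the scatter), its furthest by the step of a 13-fold higher number from compound 1 to compound 2 (1.11 log units; beyond the scatter). Compound 4 `CSc1ccc(C2=C(c3ccccc3)C(=O)N3CCCC3C2)cc1` differs from compound 1 by methylsulfanyl in place of methoxy on an aromatic carbon. The measured steps all alter the group on the double-bonded ring carbon, so none of them touches the part of the molecule that changes here; they offer no direct guidance. With the shared core and the other ring unchanged, the expectation is no step beyond the scatter, a 1.0-fold higher number from compound 1 to compound 4 (0.01 log units; within the scatter). Compound 4 is therefore estimated at 400 nM, in the range 150 nM to 1200 nM.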

Compound 4, half-maximal inhibitory concentration: 1000 nM
For compound 4 the middle estimate is 2.5-fold (0.40 log units) below the measured one; the measured number falls inside the stated range.
By their numbers in this assay, from the lowest: compound 1; then compound 4; then compounds 3 and 2 (each within the scatter of the next).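

Until now, every step changed the group on the double-bonded ring carbon. This one shows that the para group on the other aromatic ring also matters in this assay: methylsulfanyl in place of methoxy gives a 2.6-fold higher number from compound 1 to compound 4 (0.41 log units; beyond the scatter), a shift beyond the scatter from exchanging oxygen for sulfur alone. Nothing available explains this shift.

Still open, going by these compounds, is how a hydroxyl, a chlorine atom or a dimethylamino group would fare at this position. It is also unclear whether methylsulfanyl would have the same effect alongside thiophen-2-yl or furan-3-yl.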